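Swapping the amide substituent: thiazole to pyridinecarbonyl hydrazide

The source may hold more compounds than are shown below. What is called first, only, known or untested is meant among the compounds shown, and "the series" means these compounds.

Measured compounds and values:
- Compound 1, `COc1ccc2nc(C)cc(OCC(=O)Nc3cc(C)ccc3OC)c2c1`: 9500 nM
- Compound 2, `COc1ccc2nc(C)cc(OCC(=O)Nc3ccncn3)c2c1`: 27500 nM
- Compound 3, `COc1ccc2nc(C)cc(OCC(=O)Nc3nccs3)c2c1`: 54000 nM

All three share one core and differ only in the group on the amide-type nitrogen. In a physicochemical assay for solubility, in phosphate buffer, measured as kinetic solubility, with a stated time of 1 h, at pH 7.4 (on this read-out higher numbers stand for higher solubility and lower numbers for lower solubility), compound 3 gives the highest number of the three. Its margin over compound 1 is clear, shown by a 5.7-fold higher number from compound 1 to compound 3 (0.75 log units; beyond the scatter), whereas the gap to compound 2, given by a 2.0-fold higher number from compound 2 to compound 3 (0.29 log units; within the scatter), lies within the scatter, so compound 3 and compound 2 cannot be ranked against each other. The step of a 2.9-fold higher number from compound 1 to compound 2 (0.46 log units; beyond the scatter) completes the picture: both small heteroaryl groups gave more soluble compounds than the 2-methoxy-5-methylphenyl group.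

Compound 4, `COc1ccc2nc(C)cc(OCC(=O)NNC(=O)c3ccncc3)c2c1`, has not yet been measured. It carries ((pyridin-4-yl)carbonyl)amino in place of 1,3-thiazol-2-yl on an amide-type nitrogen. For the measured compounds named here, no measured step involves a group of this kind; the steps above only show that leaving the 2-methoxy-5-methylphenyl group raised the number, and the entering group here is larger and brings a hydrogen-bond donor. Compound 4 is therefore expected to stay near compound 3, with a 1.1-fold higher number from compound 3 to compound 4 (0.05 log units; within the scatter) as the estimated change, which may fall within the scatter. The estimate for compound 4 is 60000 nM, within 25000 nM to 150000 nM.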

Compound 4, solubility: >= 375000 nM
Compound 4: only a limit was reported (the forecaster's own chance of this, stated with the estimate: 15%); at least 6.2-fold (0.79 log units) between middle value and limit.
By their numbers in this assay, from the lowest: compound 1; then compounds 2 and 3 (each within the scatter of the next). At a limit, above all of these: compound 4.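

In this assay compound 4 gives a limit of the assay and not a number: the limit of >= 375000 nM in this assay, at which 1 of the 4 values shown sits.

The earlier compounds shown here showed only ring-for-ring swaps on the amide-type nitrogen, and the two small heteroaryl groups there could not be told apart, whereas ((pyridin-4-yl)carbonyl)amino, which places a carbonyl and a further nitrogen before its ring, gives a clear rise over all three, with an at least 6.9-fold higher number from compound 3 to compound 4 (0.84 log units; beyond the scatter) and with an at least 13-fold higher number from compound 2 to compound 4 (1.13 log units; beyond the scatter) and with an at least 39-fold higher number from compound 1 to compound 4 (1.59 log units; beyond the scatter). For the compounds shown here, this position can therefore carry more than a directly attached ring, and the change from 1,3-thiazol-2-yl, with 5 heavy atoms and 0 hydrogen-bond donors, to a group with 9 heavy atoms and 1 hydrogen-bond donor goes with a much larger step than any seen among the earlier compounds.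

The pyridin-4-yl ring, the carbonyl and the added amino nitrogen all enter together, so the compounds shown do not tell which of these parts goes with the step. As far as these compounds go, whether the number would stay this high with a plain phenyl ring in place of pyridin-4-yl, or with a methyl group in place of the whole ring, also remains open.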